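The source may hold more compounds than are shown below. What is called first, only, known or untested is meant among the compounds shown, and "the series" means these compounds.

Compound 1 `Cc1cc(COc2ccccc2)nc(-c2ccccn2)n1` gives 794 nM in a functional assay on cells for antagonist activity at Free fatty acid receptor 1 (Homo sapiens), read by TR-FRET and inositol phosphate accumulation, with a stated time of 2 h; on this read-out higher numbers stand for weaker inhibition and lower numbers for stronger inhibition.
Compound 2 `Cc1cc(COc2ccccc2F)nc(-c2ccccn2)n1` gives 398 nM in this assay.
Compound 3 `Cc1cc(COc2ccc(F)c(F)c2)nc(-c2ccccn2)n1` gives 501 nM in this assay.

Compound 2 differs from compound 1 by fluoro in place of hydrogen on an aromatic carbon, and that change produced a 2.0-fold lower number from compound 1 to compound 2 (0.30 log units; within the scatter). The difference between the core of compound 1 and the core of compound 3 is not broken down here. Compound 4 `Cc1cc(COc2cc(F)c(F)cc2F)nc(-c2ccccn2)n1`, not yet measured, differs from compound 3 by fluoro in place of hydrogen on an aromatic carbon. This is the same kind of change as that from compound 1 to compound 2, though the surroundings differ: in compound 4 the new fluoro sits meta to a fluoro group and para to a fluoro group, whereas in compound 2 it is only ortho to a large group. Because a 2.0-fold lower number from compound 1 to compound 2 (0.30 log units; within the scatter) was modest, a step of similar size or smaller is expected, namely a 1.6-fold lower number from compound 3 to compound 4 (0.19 log units; within the scatter). Compound 4 is therefore estimated at 320 nM in this assay, with a likely range from 150 nM to 700 nM.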

Compound 4, half-maximal inhibitory concentration: 398 nM
Compound 4: middle estimate off by 1.2-fold (0.09 log units), on the low side; the measured number falls inside the stated range.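

Fluoro in place of hydrogen on an aromatic carbon gives a 1.3-fold lower number from compound 3 to compound 4 (0.10 log units; within the scatter) in this assay. Set beside the earlier step, the new one does not differ from it beyond what repeated measurements would give: the same change on two cores in this assay, a 2.0-fold lower number (0.30 log units; within the scatter) from compound 1 to compound 2 and a 1.3-fold lower number (0.10 log units; within the scatter) from compound 3 to compound 4, 1.6-fold (0.20 log units) apart, within the scatter of two such steps

The change therefore behaves alike on these two cores, but each step lies within the scatter on its own, so the pair does not show that fluoro shifts the number at all, nor does it set a rule for other cores in the series.

The compounds shown leave open whether a different group on the same ring, such as a chloro, a methoxy or an amine, would give a step beyond the scatter. As far as these compounds go, how a carboxylic acid on the shared core would fare also remains open.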